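A few compounds are considered here, and "the series" means these few. Any claim that something is new, unique, unknown or untested is made for them only; others in the source may bear on it.

Measured so far:
Compound 1 `O=C(/C(=C\c1cc(I)c(O)c(I)c1)SCc1ccc(Br)cc1)c1ccc(Br)cc1`: 1000 nM
Compound 2 `COc1cc(/C=C(/SCc2ccc(Br)cc2)C(=O)c2ccc(Br)cc2)cc([N+](=O)[O-])c1O`: 25000 nM

In a functional assay on DU-145 cells (Homo sapiens) for inhibition, read by trypan blue exclusion, with a stated time of 96 h (a higher number here means a weaker inhibitor of growth, a lower number a stronger inhibitor of growth), compound 1 holds the lower of the two numbers, and compound 2 lies above it by more than the scatter. Compound 3 `O=C(/C(=C\c1cc(Br)c(O)c(Br)c1)SCc1ccc(Br)cc1)c1ccc(Br)cc1` has not yet been measured. It carries 3,5-dibromo-4-hydroxyphenyl in place of 4-hydroxy-3,5-diiodophenyl on a double-bonded chain carbon bound to a double-bonded chain carbon. Going by the values given here, no measured pair shows this change, so no shift beyond the scatter is expected in this assay. The estimated step is a 1.2-fold higher number from compound 1 to compound 3 (0.08 log units; within the scatter). For compound 3 the expected value is 1200 nM, with an estimated range of 400 nM to 4000 nM.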

Compound 3, concentration for 50% growth inhibition: 1000 nM
Estimate against measurement, compound 3: 1.2-fold (0.08 log units) above; the range from low to high includes it.
By their numbers in this assay, from the lowest: compounds 1 and 3 (each within the scatter of the next); then compound 2.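

In this assay, placing 3,5-dibromo-4-hydroxyphenyl in place of 4-hydroxy-3,5-diiodophenyl on a double-bonded chain carbon bound to a double-bonded chain carbon gives no change at the digits printed from compound 1 to compound 3 (within the scatter), so iodine and bromine are interchangeable at this place in this read-out. Going by these compounds alone, this is the first pair here that differs in one place, and so the first direct reading of this position. Nothing measured here bears on why the two groups match. The compounds shown leave open whether chlorine or methyl could stand in place of the bromine, and whether a methoxy group could replace the hydroxy group with the halogens kept.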